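This account rests on a few compounds, and the source may have more. Where it says the series, first, only, none or still open, it means among the compounds named here.

Compound 1, `CC(=O)Nc1c(C)nc2c(OCc3ccccc3)cccn12`, serves as the reference point for the series. In a functional assay on the whole organism with Canis familiaris (Canis lupus familiaris) as the target, at a dose of 8 mg/kg by the oral route (on this read-out higher numbers stand for a stronger effect at the one dose given and lower numbers for a weaker effect), compound 1 gives 44%. Compound 3, `CCNc1c(C)nc2c(OCc3ccccc3)cccn12`, carries the change (ethyl in place of acetyl on a nitrogen on an aromatic ring); in this assay compound 3 gives 68%. The step from the first of these to the second is a number 24 percentage points higher from compound 1 to compound 3 (beyond the scatter).

Compound 2, `CC(=O)Nc1c(C)nc2c(CCc3ccccc3)cccn12`, shares the acetamido group of compound 1 but rests on a different core; the difference between the two cores is not broken down here. In this assay, going by the values given here, compound 2 gives 16%, the lowest of the three numbers measured so far, and its distance from compound 3 is the widest in the set.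

Compound 4, `CCNc1c(C)nc2c(CCc3ccccc3)cccn12`, has not yet been measured. It differs from compound 2 by ethyl in place of acetyl on a nitrogen on an aromatic ring. The place of this change is described in the same words as for the pair compound 1 to compound 3, so it is the same change, made on the core of compound 2 rather than the core of compound 1.

Among the compounds with values here, the expected step from compound 2 to compound 4 in this assay is a number 22 percentage points higher from compound 2 to compound 4 (beyond the scatter), which rests on the measured a number 24 percentage points higher from compound 1 to compound 3 (beyond the scatter) as the only precedent for this change. Compound 4 is therefore estimated at 38% in this assay, with an expected range from 18% to 58%, the width reflecting that the carry-over of one step onto a different core is supported by a single pair only.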

Compound 4, a percentage reported as inhibition, in the whole organism at one dose (the size of the read-out at that dose, not a potency): 65%
Compound 4: middle estimate off by 27 percentage points, on the low side; the measured number lies above the stated range.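

In this assay, ethyl in place of acetyl on the core of compound 2 gives a number 49 percentage points higher from compound 2 to compound 4 (beyond the scatter), so the direction of the change seen on the core of compound 1 carries over to a second core. The size of the step does not carry over, and a step measured on one core is a poor guide to its size on the other: the same change on two cores in this assay, a number 24 percentage points higher (beyond the scatter) from compound 1 to compound 3 and a number 49 percentage points higher (beyond the scatter) from compound 2 to compound 4, 25 percentage points apart, beyond the scatter of two such steps

These two pairs show neither what sets the size of the step nor how it would behave on any further core, and the read-out at one dose is not a potency, so the notes support a shared direction across these two cores only; with ethylamino in place, compound 3 gives 68% and compound 4 gives 65%.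

The compounds shown leave open how a longer chain such as propyl or butyl, a methyl group or an unsubstituted amine on that nitrogen would read in this assay, and so whether the step is particular to ethyl. They also leave open whether the same direction would hold at other doses, since each compound appears here at a single dose.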